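The compounds below may be only part of what the source reports. "The series", "measured", "known", "first", "only" and "open" are said of these compounds alone.

Values so far in an ADME assay on liver for metabolic stability, with Liver microsome (Homo sapiens) as the target, using microsomes; on this read-out higher numbers stand for fast clearance and lower numbers for slow clearance

compound 1 `O=C(Nc1cc(-c2ccccn2)n[nH]1)N1CCC(Oc2ccccc2)CC1` gives 27.3 mL.min-1.g-1
compound 2 `O=C(Nc1cc(-c2ccccn2)n[nH]1)N1CCC(c2cccc(Cl)c2)CC1` gives 30.8 mL.min-1.g-1
compound 3 `O=C(Nc1cc(-c2ccccn2)n[nH]1)N1CCC(Oc2ccccn2)CC1` is not yet measured

Compound 2 at 30.8 mL.min-1.g-1 lies within the scatter of compound 1, and the two cannot be separated on these numbers. The change now in view is (pyridin-2-yl)oxy in place of 3-chlorophenyl on a saturated ring carbon.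

Among the measured compounds shown here, only one measured step bears on it: a 1.1-fold higher number from compound 1 to compound 2 (0.05 log units; within the scatter). That step exchanged phenoxy for 3-chlorophenyl at the same ring carbon, and it stays within the scatter. So far, then, this position has shown no measurable movement in this assay. For the measured compounds named here, this is a single step, however, and no measured compound carries (pyridin-2-yl)oxy, so its own effect remains unknown. A step beyond the scatter is therefore not expected, although the range is left wide, more so toward lower numbers.

The estimated step is a 1.5-fold lower number from compound 2 to compound 3 (0.17 log units; within the scatter).

For compound 3 the expected value is 21 mL.min-1.g-1, with an estimated range of 10 mL.min-1.g-1 to 38 mL.min-1.g-1.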

Compound 3, intrinsic clearance in microsomes: < 11.9 mL.min-1.g-1
Compound 3: only a limit was reported; the forecaster's own chance of this, stated with the estimate: 3%; at least 1.7-fold (0.24 log units) between middle value and limit.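

Working notes on the position three ring bonds from the ring nitrogen: this position is no longer silent in this assay, since the change to (pyridin-2-yl)oxy gives an at least 2.5-fold lower number from compound 2 to compound 3 (0.41 log units; beyond the scatter), whereas the earlier exchange of phenoxy for 3-chlorophenyl stayed within the scatter. With the oxygen kept in place, pyridin-2-yl in place of phenyl is by itself enough to separate the compounds, giving an at least 2.2-fold lower number from compound 1 to compound 3 (0.36 log units; beyond the scatter). For compound 3 the reported figure is a limit: the limit of < 11.9 mL.min-1.g-1 in this assay, at which 1 of the 3 values shown sits.

The compounds shown do not tell whether this step follows the ring nitrogen as such or its place in the aromatic ring, a question that pyridin-3-yl on the same oxygen would address. From the compounds shown here alone, they also leave open whether a pyrimidin-2-yl group on that oxygen, or a pyridin-2-yl group joined directly to the saturated ring carbon, would carry the same step, and all three compounds share one core, so the reach of this step beyond that core remains unknown.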